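A few compounds are considered here, and "the series" means these few. Any claim that something is new, unique, unknown or untested is made for them only; others in the source may bear on it.

For the measured compounds named here, compound 1 (`COc1ccc(Nc2nc(-n3ccnc3C)cs2)cc1`) gives 1600 nM in a functional assay on RKO cells (Homo sapiens) for cytotoxicity, read by resazurin assay, with a stated time of 72 h (a higher number here means a weaker inhibitor, a lower number a stronger inhibitor), and holds the lowest of the three numbers measured so far. In this assay compound 2 (`Cc1nccn1-c1csc(Nc2ccc(Br)cc2)n1`) gives 30000 nM and compound 3 (`Cc1nccn1-c1csc(Nc2ccccc2)n1`) gives 32500 nM on the same scale.

Compound 4 (`COc1ccc(Nc2nc(-n3ccnc3)cs2)cc1`) departs from compound 1 in a new place, with hydrogen in place of methyl on an aromatic carbon of a five-membered aromatic ring with 2 nitrogen. Going by the values given here, all the measured steps change a different group: a 19-fold higher number from compound 1 to compound 2 (1.27 log units; beyond the scatter) comes with bromo in place of methoxy, a 20-fold higher number from compound 1 to compound 3 (1.31 log units; beyond the scatter) with hydrogen in place of methoxy, and a 1.1-fold higher number from compound 2 to compound 3 (0.03 log units; within the scatter) with hydrogen in place of bromo. Among the compounds with values here, none of them touches this methyl, so they show only that a single swap can matter and give no direct size or direction here. Both changes made to compound 1 so far raised the number, so a modest rise is the cautious expectation, with a wide range. The expected step is a 1.8-fold higher number from compound 1 to compound 4 (0.24 log units; within the scatter) in this assay on this reasoning. Compound 4 is estimated at 2800 nM with an expected range from 900 nM to 10000 nM in this assay for now.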

Compound 4, half-maximal inhibitory concentration: > 100000 nM
Compound 4: only a limit was reported; the forecaster's own chance of this, stated with the estimate: 5%; middle value at least 35-fold (1.55 log units) away from the limit.
By their numbers in this assay, from the lowest: compound 1; then compounds 2 and 3 (each within the scatter of the next). At a limit, above all of these: compound 4.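

For the compounds shown here, this is the first change on the carbon between two ring nitrogen atoms, and in this assay replacing the methyl with hydrogen gives an at least 62-fold higher number from compound 1 to compound 4 (1.79 log units; beyond the scatter). The earlier steps shown here all changed the methoxy or the group standing in its place, so they could not show that this single methyl, one carbon atom in all, matters so much to the activity of compound 1. The value for compound 4 is a limit and not a number: the limit of > 100000 nM in this assay, at which 1 of the 4 values shown sits.

The compounds shown hold only methyl or hydrogen on this carbon, so what an ethyl group, a longer chain or an amine would give there remains open. On these data alone, whether removing the methyl matters as much in compound 2 or compound 3 also remains open.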